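The source may report more compounds than this note shows. Statements on the series, on what has been measured and on what is new or still open speak of the compounds shown alone.

Compound 1 `COc1ccc(-c2nc(-c3ccccc3)c(-c3ccc4c(c3)NC(=O)CO4)[nH]2)cc1`: 108%
Compound 2 `COc1ccc(-n2cc(-c3ccccc3)c(-c3ccc4c(c3)NC(=O)CO4)n2)cc1`: 106%
Compound 3 `Cc1ccccc1-n1cc(-c2ccccc2)c(-c2ccc3c(c2)NC(=O)CO3)n1`: 99.4%

In a functional assay on MV4-11 cells (Homo sapiens) for cytotoxicity, read by colorimetric assay and MTT assay, with a stated time of 3 days, tested at 1 uM (on this read-out higher numbers stand for a weaker effect at the one concentration tested and lower numbers for a stronger effect), compound 3 gives 99.4%, the lowest of the three numbers, though its gaps to compound 2 and to compound 1 are both within the scatter of repeated measurements. All three compounds thus leave the cells essentially untouched at the one concentration tested.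

Compound 4 `O=C1COc2ccc(-c3nn(-c4ccc(Br)cc4)cc3-c3ccccc3)cc2N1` has not yet been measured. It differs from compound 3 in one place: 4-bromophenyl in place of 2-methylphenyl on an aromatic nitrogen

For the measured compounds named here, the only measured step at the same place is a number 6.6 percentage points lower from compound 2 to compound 3 (within the scatter), which stayed within the scatter. Going by the values given here, nothing among the measured compounds shows that the group on this aromatic nitrogen moves the read-out, so compound 4 is expected to come out near the others. The expected step of a number 0.6 percentage points higher from compound 3 to compound 4 (within the scatter) is therefore small, with no direction beyond the scatter. For compound 4 the estimate in this assay is 100%, with a range from 85% to 115%.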

Compound 4, a percentage reported as activity, at one concentration (the size of the read-out at that concentration, not a potency): 108%
Compound 4: the middle estimate sits 8 percentage points below what was measured, within the range that was stated.
By their numbers in this assay, from the lowest: compounds 3, 2, 1 and 4 (each within the scatter of the next).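

In this assay, the new aryl group on the aromatic nitrogen gives a number 8.6 percentage points higher from compound 3 to compound 4 (within the scatter), and bromo in place of methoxy on the same kind of phenyl ring gives a number 2 percentage points higher from compound 2 to compound 4 (within the scatter), so neither change separates from the scatter. For the compounds shown here, this position now carries three different aryl groups, 4-methoxyphenyl, 2-methylphenyl and 4-bromophenyl, and all of them leave the read-out indistinguishable at the one concentration tested, where the earlier compounds offered only a single step here. No supporting data are available to explain this flat result.

The compounds shown leave open whether anything other than a substituted phenyl ring on this nitrogen, such as a longer chain ending in an amine, would change the read-out. From the compounds shown here alone, it also remains open whether a carboxylic acid on that phenyl ring would do so.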